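A few compounds are considered here, and "the series" means these few. Any claim that something is new, unique, unknown or untested is made for them only; others in the source may bear on it.

Going by the values given here, compound 2 `Cc1nn(C)c(Oc2ccc(Cl)cc2)c1/C=N\CCCCCCOc1cc2oc(=O)cc(C)c2cc1Cl` carries a 4-chlorophenoxy group; in a functional assay on U-87MG ATCC cells for antiproliferative activity against U-87 MG (Homo sapiens), read by MTT assay, with a stated time of 72 h (on this read-out higher numbers stand for weaker inhibition and lower numbers for stronger inhibition), compound 2 gives 3850 nM, the only number among the two values shown. Compound 1 `Cc1nn(C)c(Oc2cccc(F)c2F)c1/C=N\CCCCCCOc1cc2oc(=O)cc(C)c2cc1Cl` stands at > 25000 nM in this assay, which is a limit rather than a number. Compound 3 `Cc1nn(C)c(Oc2ccc(I)cc2)c1/C=N\CCCCCCOc1cc2oc(=O)cc(C)c2cc1Cl` differs from compound 2 by iodo in place of chloro on an aromatic carbon. Among the compounds with values here, the single measured step, an at least 6.4-fold lower number from compound 1 to compound 2 (0.81 log units; beyond the scatter), altered the substitution pattern of the phenoxy ring rather than swapping one halogen for another, so it bears only loosely on the present change. A step within the scatter, perhaps a slight gain, is expected, a 1.3-fold lower number from compound 2 to compound 3 (0.11 log units; within the scatter). Compound 3 is estimated at 3000 nM, between 1000 nM and 9000 nM.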

Compound 3, half-maximal inhibitory concentration: 16800 nM
Beside the measured number, compound 3's estimate is 5.6-fold (0.75 log units) below it; the measured number lies above the stated range.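

Swapping one halogen for another at this place is not neutral: iodo in place of chloro gives a 4.4-fold higher number from compound 2 to compound 3 (0.64 log units; beyond the scatter), meaning weaker inhibition, which the earlier change of phenoxy substitution pattern could not show. The 4-iodophenyl group holds only an uncertain edge over 2,3-difluorophenyl, with an at least 1.4-fold lower number from compound 1 to compound 3 (0.17 log units; that floor lies within the scatter). That step gives only a floor because the value of compound 1 is a limit: the limit of > 25000 nM in this assay, at which 1 of the 3 values shown sits.

As far as these compounds go, whether bromo, fluoro or methoxy at this carbon would track chloro or iodo remains open. So does whether the chloro-over-iodo order would hold with a longer chain.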